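This account rests on a few compounds, and the source may have more. Where it says the series, first, only, none or still open, it means among the compounds named here.

Measured in an in vitro ADME assay on microsomes from liver (Homo sapiens) for pharmacokinetics, read by LC-MS, with a stated time of 10 min, tested at 1 uM (a lower number here means slower removal, a higher number faster removal of the compound), so far
Compound 1 `CN1C[C@H](C(=O)Nc2ccccc2)[C@@H](c2ccc(/C=C/C(=O)Nc3ccccc3N)cc2)C1` gives 7 mL/min/kg
Compound 2 `COc1ccc(NC(=O)[C@H]2CN(C)C[C@@H]2c2ccc(/C=C/C(=O)Nc3ccccc3N)cc2)cc1` gives 14 mL/min/kg
Compound 3 `Cc1cccc(NC(=O)[C@H]2CN(C)C[C@@H]2c2ccc(/C=C/C(=O)Nc3ccccc3N)cc2)c1` gives 14 mL/min/kg

Compound 3 stands level with compound 2 and within the scatter of compound 1. The steps are no change at the digits printed from compound 2 to compound 3 (within the scatter) and a 2.0-fold higher number from compound 1 to compound 3 (0.30 log units; within the scatter) on the same group.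

Next is compound 4 `CN1C[C@H](C(=O)Nc2ccc(Cl)c(Cl)c2)[C@@H](c2ccc(/C=C/C(=O)Nc3ccccc3N)cc2)C1` with 3,4-dichlorophenyl in place of 3-methylphenyl on an amide-type nitrogen. Within the data shown here, the difference is 3,4-dichlorophenyl in place of 3-methylphenyl on an amide-type nitrogen and no measured compound carries chlorine, so the guide is indirect.

The remaining step at that nitrogen is a 2.0-fold higher number from compound 1 to compound 2 (0.30 log units; within the scatter) and, like the other two, it gives no sign of a large move. The expected step is no change at the digits printed from compound 3 to compound 4 (within the scatter) with nothing beyond the scatter expected in either direction. Compound 4 is estimated at 14 mL/min/kg with an expected range from 6 mL/min/kg to 30 mL/min/kg in this assay.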

Compound 4, clearance: 14 mL/min/kg
Beside the measured number, compound 4's estimate shows no gap at the digits printed; measured number inside the range.
By their numbers in this assay, from the lowest: compounds 1, 2, 3 and 4 (each within the scatter of the next).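

Among these compounds, at the amide-type nitrogen, 3,4-dichlorophenyl brings chlorine into the set for the first time, and this assay shows no change at the digits printed from compound 3 to compound 4 (within the scatter) and no change at the digits printed from compound 2 to compound 4 (within the scatter) and a 2.0-fold higher number from compound 1 to compound 4 (0.30 log units; within the scatter). All four aryl groups at this nitrogen therefore stay within the scatter of one another, now including a ring carrying chlorine. No evidence on the cause of this result is available. A pyridyl ring, a carboxylic acid or an aminoalkyl chain at this nitrogen is not among the compounds shown. From the compounds shown here alone, whether any of these would move clearance beyond the scatter remains open.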